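The compounds below may be only part of what the source reports. "The series", "measured", "known", "first", "only" and "open" are said of these compounds alone.

Measured so far in a physicochemical assay for solubility, read by HPLC, measured as thermodynamic solubility, with a stated time of 4 h, at pH 6.8; on this read-out lower numbers stand for lower solubility and higher numbers for higher solubility:

compound 1, `Cc1ccc(Oc2ccc3nc(COc4cccc(C(=O)O)c4)n(C)c3n2)cc1`, 33 ug/mL
compound 2, `Cn1c(COc2cccc(C(=O)O)c2)nc2cnc(Oc3ccc4c(c3)CCC4)cc21`, 70 ug/mL
compound 3, `Cn1c(COc2cccc(C(=O)O)c2)nc2ccc(Oc3ccc(Cl)cn3)cc21`, 17 ug/mL

Compound 3 stands at the low end of these three numbers. Its gap to compound 1 lies within the usual scatter of the method, so the two cannot be told apart, while its gap to compound 2 lies beyond the scatter, and compound 2 is the one that clearly dissolves better.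

Compound 4, `Cn1c(COc2cccc(C(=O)O)c2)nc2ccc(Oc3ncccc3Cl)cc21`, has not yet been measured. It differs from compound 3 in one place: 3-chloropyridin-2-yl in place of 5-chloropyridin-2-yl on an oxygen on an aromatic ring. The two compounds contain the same atoms joined differently, so only the position of the chlorine on the pyridine ring changes. Going by the values given here, no measured pair in this set shows what such a rearrangement does, so the expectation rests on the closeness of the two structures alone.

Compound 4 is expected to stay close to compound 3, with a step of a 1.2-fold higher number from compound 3 to compound 4 (0.07 log units; within the scatter) that does not clearly leave the scatter. The estimated value for compound 4 is 20 ug/mL, with a likely range from 8 ug/mL to 50 ug/mL.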

Compound 4, solubility: 15 ug/mL
Beside the measured number, compound 4's estimate is 1.3-fold (0.12 log units) above it, within the range that was stated.
By their numbers in this assay, from the lowest: compounds 4, 3 and 1 (each within the scatter of the next, the first and the last beyond it); then compound 2.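

In this assay, 3-chloropyridin-2-yl in place of 5-chloropyridin-2-yl on an oxygen on an aromatic ring gives a 1.1-fold lower number from compound 3 to compound 4 (0.05 log units; within the scatter) and so leaves the two compounds indistinguishable. Compounds 3 and 4 are the only pair shown that differ in one place, which makes this the only direct reading of a change at this position, and it shows that moving the chlorine between these two places on the pyridine ring produces no difference that can be told from the scatter. Nothing available here explains this result.

As far as these compounds go, whether a chlorine elsewhere on the ring, or another group such as an amine or a nitrile, would read the same remains open. One pair also cannot show whether these two chlorine positions would read alike on a different core, such as that of compound 1.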